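Swapping 3-aminophenyl for 2-fluorophenyl on a shared core

A few compounds are considered here, and "the series" means these few. Any claim that something is new, unique, unknown or untested is made for them only; others in the source may bear on it.

Three compounds on one shared core have numbers in a functional assay (muscle tissue) with Cavia porcellus as the target (a higher number here means that more compound is needed for the effect, a lower number that less compound is needed), so far. Compound 1 `COC(=O)C1=C(C)N=C(C)/C(=C(\O)OC)C1c1cccc(OC)c1` gives 191 nM and compound 2 `COC(=O)C1=C(C)N=C(C)/C(=C(\O)OC)C1c1ccccc1I` gives 46.8 nM here. Compound 3 `COC(=O)C1=C(C)N=C(C)/C(=C(\O)OC)C1c1cccc(N)c1` stands highest of the three at 2000 nM and so needs the most compound. Compound 4 `COC(=O)C1=C(C)N=C(C)/C(=C(\O)OC)C1c1ccccc1F` is not yet measured. It carries 2-fluorophenyl in place of 3-aminophenyl on a saturated ring carbon and the rest stays the same. The nearest match to the new group is 2-iodophenyl, and changing that to 3-aminophenyl gave a 43-fold higher number from compound 2 to compound 3 (1.63 log units; beyond the scatter) in these data. Replacing methoxy by amino gave a 10-fold higher number from compound 1 to compound 3 (1.02 log units; beyond the scatter) as well. A large drop is therefore expected in this assay with a 25-fold lower number from compound 3 to compound 4 (1.40 log units; beyond the scatter) as the estimated step. Compound 4 is estimated at 80 nM within a range of 25 nM to 260 nM for this measurement.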

Compound 4, half-maximal effective concentration: 42.7 nM
Compound 4: the middle estimate sits 1.9-fold (0.27 log units) above what was measured, within the range that was stated.
By their numbers in this assay, from the lowest: compounds 4 and 2 (each within the scatter of the next); then compound 1; then compound 3.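

In this assay, fluoro and iodo on the phenyl ring are interchangeable, with a 1.1-fold lower number from compound 2 to compound 4 (0.04 log units; within the scatter). The 2-fluorophenyl group also stands apart from both other groups, with a 47-fold lower number from compound 3 to compound 4 (1.67 log units; beyond the scatter) and a 4.5-fold lower number from compound 1 to compound 4 (0.65 log units; beyond the scatter), so the low numbers now hold for two different 2-halophenyl groups rather than one. Nothing measured here explains these steps. Each of those two larger steps changes both the group and its place on the phenyl ring, so a 2-aminophenyl or 3-fluorophenyl group would be needed to tell those two changes apart.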